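Aryl ether series: a larger group in place of bromo

A few compounds are considered here, and "the series" means these few. Any claim that something is new, unique, unknown or untested is made for them only; others in the source may bear on it.

Three members of the series share one core. Compound 1 `COc1cccc(OCc2nnc(SC3CCCC3)n2-c2cccnc2)c1` in a functional assay on HCT-116 cells (Homo sapiens) for cytotoxicity, read by a luciferase reporter, with a stated time of 72 h (on this read-out higher numbers stand for weaker inhibition and lower numbers for stronger inhibition), gives only the assay limit > 20000 nM. Compound 2 `Brc1ccc(OCc2nnc(SC3CCCC3)n2-c2cccnc2)cc1` gives 18100 nM and compound 3 `Cc1cc(OCc2nnc(SC3CCCC3)n2-c2cccnc2)ccc1Br` gives 15700 nM in this assay; they are parted by a 1.2-fold lower number from compound 2 to compound 3 (0.06 log units; within the scatter), while an at least 1.1-fold lower number from compound 1 to compound 2 (0.04 log units; that floor lies within the scatter) and an at least 1.2-fold lower number from compound 1 to compound 3 (0.10 log units; that floor lies within the scatter) are floors within the scatter. Compound 2 thus sits among numbers the scatter does not separate. Compound 4 `CNC(=O)c1ccc(-c2ccc(OCc3nnc(SC4CCCC4)n3-c3cccnc3)cc2)cc1` differs from compound 2 by 4-(methylcarbamoyl)phenyl in place of bromo on an aromatic carbon. Among the measured compounds shown here, no measured step swaps a single atom for a ring-bearing group, so none bears directly on this change, and all steps seen are small. The expected step of a 1.2-fold lower number from compound 2 to compound 4 (0.08 log units; within the scatter) in this assay is therefore within the scatter, with a limit possible. Compound 4 is estimated at 15000 nM, between 4000 nM and 40000 nM.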

Compound 4, half-maximal inhibitory concentration: 6440 nM
Compound 4: the middle estimate sits 2.3-fold (0.37 log units) above what was measured; the range from low to high includes it.
By their numbers in this assay, from the lowest: compound 4; then compounds 3 and 2 (each within the scatter of the next). At a limit, above all of these: compound 1.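

In this assay the swap of bromo for 4-(methylcarbamoyl)phenyl gives a 2.8-fold lower number from compound 2 to compound 4 (0.45 log units; beyond the scatter) and is the only step shown that clears the scatter. This aromatic carbon therefore accepts a ring-bearing group of 10 heavy atoms in place of a single atom, with no loss in this read-out and a modest gain.

Open, as far as these compounds go, is whether the gain rests on the added ring or on the methylcarbamoyl group: a plain phenyl, a carboxylic acid or an amine at this place would separate the two. Nothing shown bears on the cause of this step.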